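This account rests on a few compounds, and the source may have more. Where it says the series, first, only, none or still open, it means among the compounds named here.

Three compounds on the shared core have numbers in a functional assay on HeLa cells (Homo sapiens) for cytotoxicity, read by WST assay, with a stated time of 48 h; on this read-out higher numbers stand for weaker inhibition and lower numbers for stronger inhibition: compound 1 (`O[C@@H](c1ccccc1)[C@H]1CO[C@H](c2ccccc2)[C@@H](C/C=C/c2cccc(F)c2)C1`) gives 8380 nM, compound 2 (`O=[N+]([O-])c1ccc(/C=C/C[C@H]2C[C@@H]([C@@H](O)c3ccccc3)CO[C@@H]2c2ccccc2)cc1`) gives 12400 nM and compound 3 (`O[C@@H](c1ccccc1)[C@H]1CO[C@H](c2ccccc2)[C@@H](C/C=C/C2CCCCC2)C1`) gives 6440 nM. On these numbers, compound 3 is not separated from the other two.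

Compound 4 (`O[C@@H](c1ccccc1)[C@H]1CO[C@H](c2ccccc2)[C@@H](C/C=C/c2ccccc2F)C1`) is still unmeasured. It has 2-fluorophenyl in place of cyclohexyl on a double-bonded chain carbon bound to a double-bonded chain carbon.

Two measured steps exchange an aromatic group and cyclohexyl at this place: a 1.3-fold lower number from compound 1 to compound 3 (0.11 log units; within the scatter) and a 1.9-fold lower number from compound 2 to compound 3 (0.28 log units; within the scatter). The exchange between the two aromatic groups is also small: a 1.5-fold higher number from compound 1 to compound 2 (0.17 log units; within the scatter). All three stay within the scatter, so no step beyond the scatter is expected in this assay. For the measured compounds named here, no 2-fluorophenyl compound has been measured, so this rests on three compounds only.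

The closest measured group is the 3-fluorophenyl of compound 1, at 8380 nM, and the estimate leans towards that number. The expected step is a 1.2-fold higher number from compound 3 to compound 4 (0.09 log units; within the scatter). For compound 4 the estimated value is 8000 nM, with an expected range of 4000 nM to 16000 nM.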

Compound 4, half-maximal inhibitory concentration: 9730 nM
Beside the measured number, compound 4's estimate is 1.2-fold (0.09 log units) below it; the range from low to high includes it.
By their numbers in this assay, from the lowest: compounds 3, 1, 4 and 2 (each within the scatter of the next).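

In this assay, 2-fluorophenyl on a double-bonded chain carbon bound to a double-bonded chain carbon stays within the scatter of each of the three groups already seen at this place (a 1.5-fold higher number from compound 3 to compound 4 (0.18 log units; within the scatter); a 1.3-fold lower number from compound 2 to compound 4 (0.11 log units; within the scatter); a 1.2-fold higher number from compound 1 to compound 4 (0.06 log units; within the scatter)). The 2-fluorophenyl and 3-fluorophenyl groups are therefore not told apart, and the four compounds, with one non-aromatic and three aromatic rings at this place, show no separation among these groups. No available evidence bears on this result.

As far as these compounds go, all four compounds carry a six-membered ring of carbon at this place, so the effect of an amine, a carboxylic acid or a longer chain there remains open. Changes elsewhere on the shared core also remain open.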